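Predicting a Methyl Step in a Cytotoxicity Series

The source may report more compounds than this note shows. Statements on the series, on what has been measured and on what is new or still open speak of the compounds shown alone.

Measured so far:
compound 1, `Cc1ccc(CSc2cc(Cl)c(C)cc2S(=O)(=O)/N=C(\N)n2nc(C)cc2-c2ccccc2)cc1`, gives in a functional assay on MCF7 cells (Homo sapiens) for cytotoxicity, read by MTT assay, with a stated time of 72 h (a higher number here means a weaker inhibitor, a lower number a stronger inhibitor), a value of 89000 nM
compound 2, `Cc1ccc(CSc2cc(Cl)c(C)cc2S(=O)(=O)/N=C(\N)n2nccc2-c2ccccc2)cc1`, gives in this assay a value of 21000 nM
compound 3, `Cc1cc(S(=O)(=O)/N=C(\N)n2nccc2-c2ccccc2)c(SCc2ccccc2C(F)(F)F)cc1Cl`, gives in this assay a value of 21000 nM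

Compound 4, `Cc1cc(-c2ccccc2)n(/C(N)=N/S(=O)(=O)c2cc(C)c(Cl)cc2SCc2ccccc2C(F)(F)F)n1`, has not yet been measured in this assay. It differs from compound 3 by methyl in place of hydrogen on an aromatic carbon. The same change has already been made once, from compound 2 to compound 1, where it is methyl in place of hydrogen on an aromatic carbon, and in this assay that step was a 4.2-fold higher number from compound 2 to compound 1 (0.63 log units; beyond the scatter). The place lines of the two changes agree word for word, so the change is taken as the same in both pairs. The cores of compound 2 and compound 3 differ by 2-(trifluoromethyl)phenyl in place of 4-methylphenyl on a saturated chain carbon bound to a sulfur, and in this assay that step was no change at the digits printed from compound 2 to compound 3 (within the scatter), so compound 3 and compound 2 stand level.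

Because compound 2 to compound 1 gave a 4.2-fold higher number from compound 2 to compound 1 (0.63 log units; beyond the scatter), the same change is expected to move compound 3 by a similar amount, estimated as a 3.8-fold higher number from compound 3 to compound 4 (0.58 log units; beyond the scatter). Compound 4 is therefore expected to give about 80000 nM in this assay, with a likely range from 30000 nM to 220000 nM. This rests on a single earlier step and carries matching uncertainty.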

Compound 4, half-maximal inhibitory concentration: 101000 nM
The estimate for compound 4 lay 1.3-fold (0.10 log units) below the measured number; the range from low to high includes it.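

In this assay, the change from 5-phenyl-1H-pyrazol-1-yl to 3-methyl-5-phenyl-1H-pyrazol-1-yl gave a 4.8-fold higher number from compound 3 to compound 4 (0.68 log units; beyond the scatter), and the size of this step held from one core to the other: the same change on two cores in this assay, a 4.2-fold higher number (0.63 log units; beyond the scatter) from compound 2 to compound 1 and a 4.8-fold higher number (0.68 log units; beyond the scatter) from compound 3 to compound 4, 1.1-fold (0.05 log units) apart, within the scatter of two such steps

Read the other way around the same four compounds, putting 2-(trifluoromethyl)phenyl in place of 4-methylphenyl also gave a 1.1-fold higher number from compound 1 to compound 4 (0.05 log units; within the scatter), so with the methyl present this swap behaved as it did without it: the same change on two cores in this assay, no change at the digits printed (within the scatter) from compound 2 to compound 3 and a 1.1-fold higher number (0.05 log units; within the scatter) from compound 1 to compound 4, 1.1-fold (0.05 log units) apart, within the scatter of two such steps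

This shows that the two changes combined simply across these four compounds in this one cell assay, but it does not show that the methyl step would keep its size on cores carrying other groups, and it says nothing about why the number rises.

What the compounds shown leave open is how an ethyl group, a hydroxymethyl group or a carboxylic acid would act in place of that methyl. Also open, on these data alone, is what an amine would do in place of the phenyl group on the same ring.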